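This account rests on a few compounds, and the source may have more. Where it says the series, first, only, none or still open, it means among the compounds named here.

Measured compounds:
compound 1 `Oc1ccc(O)c(-c2cc(-c3ccc(Cl)cc3)nn2-c2ccccc2)c1`, 34600 nM
compound 2 `CC(=O)NS(=O)(=O)c1ccc(-n2nc(-c3ccccc3)cc2-c2cc(O)ccc2O)cc1`, 100000 nM
compound 3 `O=C1C=CC(=O)C(c2cc(-c3ccc(Cl)cc3)nn2-c2ccccc2)=C1`, 55800 nM

Notes. In a functional assay on cells (Cancer cell lines, Homo sapiens) for cytotoxicity, read by sulforhodamine B assay, with a stated time of 48 h (a higher number here means a weaker inhibitor of growth, a lower number a stronger inhibitor of growth), compound 1 gives 34600 nM and compound 3 gives 55800 nM; the step of a 1.6-fold higher number from compound 1 to compound 3 (0.21 log units; within the scatter) accompanies (a group of 8 heavy atoms (6 carbon, 2 oxygen; one six-membered non-aromatic ring of carbon only) in place of a group of 8 heavy atoms (6 carbon, 2 oxygen; one six-membered aromatic ring of carbon only), on an aromatic carbon). Compound 2 gives 100000 nM in this assay, the highest of the three numbers; against compound 3 the gap lies within the scatter, against compound 1 beyond it. The difference between the core of compound 1 and the core of compound 2 is not broken down here.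

Compound 4 `CC(=O)NS(=O)(=O)c1ccc(-n2nc(-c3ccccc3)cc2C2=CC(=O)C=CC2=O)cc1` is not yet measured. It carries the same kind of change as compound 3 does against compound 1: a group of 8 heavy atoms (6 carbon, 2 oxygen; one six-membered non-aromatic ring of carbon only) in place of a group of 8 heavy atoms (6 carbon, 2 oxygen; one six-membered aromatic ring of carbon only), on an aromatic carbon. The surroundings differ: in compound 1 the place is next to the ring atom that bears a phenyl group and two ring bonds from the ring atom that bears a 4-chlorophenyl group, whereas in compound 2 it is next to the ring atom that bears a large group and two ring bonds from the ring atom that bears a phenyl group.

Going by the values given here, for compound 4 in this assay a step of about a 1.2-fold higher number from compound 2 to compound 4 (0.08 log units; within the scatter) is expected, resting on the single precedent a 1.6-fold higher number from compound 1 to compound 3 (0.21 log units; within the scatter), which was within the scatter; the expected value for compound 4 is 120000 nM, between 50000 nM and 300000 nM. Compound 2 already gives 100000 nM, the highest of the three measured numbers, so the expectation for compound 4 points to a weak inhibitor of growth as well.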

Compound 4, concentration for total growth inhibition: 100000 nM
The estimate for compound 4 lay 1.2-fold (0.08 log units) above the measured number; measured number inside the range.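

In this assay, replacing the 2,5-dihydroxyphenyl group with the six-membered non-aromatic carbon ring gives no change at the digits printed from compound 2 to compound 4 (within the scatter). Set beside the earlier step on the other core, the change carries across without a difference that can be told apart: the same change on two cores in this assay, a 1.6-fold higher number (0.21 log units; within the scatter) from compound 1 to compound 3 and no change at the digits printed (within the scatter) from compound 2 to compound 4, 1.6-fold (0.21 log units) apart, within the scatter of two such steps This holds for only two pairs, and since neither step lies beyond the scatter, the notes show that the change left the number within the scatter on both cores, not that it would do so on any other core or why this is so.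

Still open, as far as these compounds go, is whether the same exchange stays within the scatter on a core bearing an amine or a carboxylic acid, or a longer alkyl chain in place of the phenyl group. Also open, from the compounds shown here alone, is how a methoxy group in place of either hydroxyl of the 2,5-dihydroxyphenyl group would read in this assay.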